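Swapping one ring on a sulfonamide nitrogen

The compounds below may be only part of what the source reports. "The series", "measured", "known", "first", "only" and "open" are said of these compounds alone.

Compound 1 `O=C1CS/C(=N/Nc2nncc3ccccc23)N1c1ccccc1` gives 44 nM
Compound 2 `O=S(=O)(Nc1ncccn1)c1ccc(Nc2nncc3ccccc23)cc1` gives 72 nM

Going by the values given here, in a functional assay on OVCAR-3 cells (Homo sapiens) for antiproliferative activity, read by sulforhodamine B assay, with a stated time of 72 h (a lower number here means a stronger inhibitor, a higher number a weaker inhibitor), compound 2 gives 72 nM and lies within the usual scatter of compound 1, the only other measured compound. Compound 3 `O=S(=O)(Nc1ccccn1)c1ccc(Nc2nncc3ccccc23)cc1` has pyridin-2-yl in place of pyrimidin-2-yl on a sulfonamide nitrogen. Among the compounds with values here, no measured pair shows this swap, so the expectation is a judgement: in this assay no step beyond the scatter is expected, in either direction. The estimate amounts to a 1.0-fold lower number from compound 2 to compound 3 (0.01 log units; within the scatter) in all. Compound 3 is estimated at 70 nM (expected range 25 nM to 200 nM).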

Compound 3, half-maximal inhibitory concentration: 83 nM
Compound 3: middle estimate off by 1.2-fold (0.07 log units), on the low side, and the stated range covers the measured number.
By their numbers in this assay, from the lowest: compounds 1, 2 and 3 (each within the scatter of the next).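

In this assay, going by these compounds alone, putting pyridin-2-yl in place of pyrimidin-2-yl on the sulfonamide nitrogen gives a 1.2-fold higher number from compound 2 to compound 3 (0.06 log units; within the scatter), the first direct reading at this position. A ring with 1 hetero atom therefore serves here as well as one with 2 hetero atoms, so this swap leaves the read-out unchanged within the scatter. Nothing available explains this result. On these data alone, it remains open whether a plain phenyl ring, with no ring nitrogen, would also be tolerated on this sulfonamide nitrogen. The same question applies to a non-aromatic group such as a morpholine or a short alkyl chain.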